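Amino for hydroxy on a purine-like core: cytotoxicity outlook

The source may report more compounds than this note shows. Statements on the series, on what has been measured and on what is new or still open speak of the compounds shown alone.

Measured compounds:
compound 1 `Nc1ncnc2c1ncn2C[C@@H]1C[C@H](O)c2ccccc21`: > 200000 nM
compound 2 `Oc1ncnc2c1ncn2C[C@@H]1C[C@H](O)c2ccccc21`: > 200000 nM
compound 3 `CC1(C)[C@@H](Cn2cnc3c(O)nc(N)nc32)CC[C@@]1(C)CO`: > 200000 nM

In an ADME assay on L1210/0 cells (Mus musculus) for cytotoxicity, with a stated time of 48 h (on this read-out higher numbers stand for weaker inhibition and lower numbers for stronger inhibition), compound 1 gives > 200000 nM, which is a limit of the assay. In this assay compound 2 gives > 200000 nM, again a limit. Compound 3 gives > 200000 nM in this assay, also a limit. The difference between compound 2 and compound 1 is amino in place of hydroxy on an aromatic carbon, and the step that the two limits leave unreadable from compound 2 to compound 1 cannot be read, since both values are limits (the limit of > 200000 nM in this assay, at which 3 of the 3 values shown sit). How the core of compound 3 differs from that of compound 2 is not broken down here.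

Compound 4 `CC1(C)[C@@H](Cn2cnc3c(N)nc(N)nc32)CC[C@@]1(C)CO` has not been measured. It differs from compound 3 by amino in place of hydroxy on an aromatic carbon, the same kind of change as from compound 2 to compound 1, though here the place is also meta to an amino group (1 heavy atom). Given that all three values sit at the limit (the limit of > 200000 nM in this assay, at which 3 of the 3 values shown sit), the expected step of a number no higher from compound 3 to compound 4 (the limit leaves the size open) is small, and compound 4 is expected to give about 200000 nM in this assay, most likely again as a limit.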

Compound 4, half-maximal inhibitory concentration: > 200000 nM
Compound 4 gave a limit, no number; the forecaster's own chance of this, stated with the estimate: 85%; the middle value sits exactly at the limit.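

Compound 3 gives > 200000 nM, a limit. Compound 4 gives > 200000 nM, also a limit, so the step between compound 3 and compound 4 cannot be read. The compounds shown leave open what size of effect amino in place of hydroxy has, if any: the limit of > 200000 nM in this assay, at which 4 of the 4 values shown sit.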